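From methoxy to fluoro: what to expect

This account rests on a few compounds, and the source may have more. Where it says the series, first, only, none or still open, it means among the compounds named here.

Values in a functional assay on Ehrlich cells (Mus musculus) for inhibition (on this read-out lower numbers stand for stronger inhibition and higher numbers for weaker inhibition), are these:
compound 1 `COc1ccc2c(O)c(C(=O)O)cnc2c1` gives 525000 nM
compound 2 `O=C(O)c1cnc2cc(OCc3ccc(Cl)c(Cl)c3)ccc2c1O` gives 15100 nM

Compound 1 has the higher number of the pair at 525000 nM and so is the weaker inhibitor of these two. The next compound to be measured, compound 3 `O=C(O)c1cnc2cc(F)ccc2c1O`, keeps the core of compound 1 but carries fluoro in place of methoxy. The change is fluoro in place of methoxy on an aromatic carbon and it sits on an aromatic carbon of a six-membered aromatic ring of carbon only, part of a fused or bridged system of two rings.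

Among the measured compounds shown here, only one measured step bears on this, and only loosely: a 35-fold lower number from compound 1 to compound 2 (1.54 log units; beyond the scatter) and it came with 3,4-dichlorophenyl in place of hydrogen on a saturated chain carbon. That large step brought in a new ring, whereas compound 3 gains none. For the measured compounds named here, no measurement yet shows what fluoro does in place of methoxy, so no direction can be argued, and no step beyond the scatter is expected in this assay for now. The expected step is a 1.1-fold lower number from compound 1 to compound 3 (0.02 log units; within the scatter) on this reasoning. For compound 3 the estimated value is 500000 nM with an expected range from 200000 nM to 1300000 nM in this assay.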

Compound 3, half-maximal inhibitory concentration: 501000 nM
Estimate against measurement, compound 3: 1.0-fold (0.00 log units) below; low and high end bracket the measured number.
By their numbers in this assay, from the lowest: compound 2; then compounds 3 and 1 (each within the scatter of the next).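

In this assay, fluoro in place of methoxy on this aromatic carbon gives a 1.0-fold lower number from compound 1 to compound 3 (0.02 log units; within the scatter), so replacing a group of 2 heavy atoms with 1 hydrogen-bond acceptor by a single fluorine atom with none leaves the number within the scatter. This adds something that the earlier step, a 35-fold lower number from compound 1 to compound 2 (1.54 log units; beyond the scatter), could not show: at this carbon, the small methoxy group can give way to fluoro, which has no oxygen, with no change beyond the scatter, while the large drop came with the 3,4-dichlorophenyl group added to the methoxy carbon. Nothing measured here explains why methoxy and fluoro read alike.

The compounds shown leave open whether other small groups on this aromatic carbon, such as an amine or a hydroxyl, would also read like methoxy and fluoro, and whether a longer chain such as butoxy would begin to lower the number. They also leave open whether the 3,4-dichlorophenyl group needs its oxygen link, which could be tested by attaching it through a plain two-carbon chain instead.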